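This account rests on a few compounds, and the source may have more. Where it says the series, first, only, none or still open, it means among the compounds named here.

Of the compounds shown here, three built on one shared core have been measured in a functional assay on CHO cells for agonist activity at Melanocyte-stimulating hormone receptor (Homo sapiens), read by a luciferase reporter, with a stated time of 4 h; a lower number here means that less compound is needed, a higher number that more compound is needed for the effect. Compound 1, `CC(C)N(C(=O)CN1C=CN(c2ccccc2)C(=O)C(Cc2n[nH]c3ccccc23)C1=O)c1ccc(OC(F)(F)F)cc1`, gives 22.4 nM. Compound 3, `O=C1[C@@H](Cc2n[nH]c3ccccc23)C(=O)N(c2ccccc2)C=CN1CC(=O)N1CCCCc2ccccc21`, gives 1.59 nM, a lower number than compound 1 by a gap beyond the usual scatter. Compound 2, `COc1ccc(N(C(=O)CN2C=CN(c3ccccc3)C(=O)C(Cc3n[nH]c4ccccc34)(OC)C2=O)C(C)C)cc1`, gives 1380 nM, a higher number than compound 1, again by a gap beyond the scatter. Compound 1 thus holds the second highest of the three numbers, closer to compound 3 than to compound 2.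

Compound 4, `CC(C)N(C(=O)CN1C=CN(c2ccccc2)C(=O)C(Cc2n[nH]c3ccccc23)C1=O)c1ccc(F)cc1`, has not yet been measured. It differs from compound 1 in one place only: fluoro in place of trifluoromethoxy on an aromatic carbon. The trifluoromethoxy group leaves and a single fluoro group enters on the same aromatic carbon, para to a large group.

Among the measured compounds shown here, no measured pair shows this change on its own, and compound 2 differs from compound 1 in more than one place, so its number cannot isolate the change. On this thin basis a modest step toward a higher number is expected, one that may not clear the scatter, so the estimated step is a 2.7-fold higher number from compound 1 to compound 4 (0.43 log units; beyond the scatter). Compound 4 is therefore expected to give about 60 nM in this assay, with a range from 15 nM to 250 nM.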

Compound 4, half-maximal effective concentration: 50.1 nM
Compound 4: middle estimate off by 1.2-fold (0.08 log units), on the high side; low and high end bracket the measured number.
By their numbers in this assay, from the lowest: compound 3; then compound 1; then compound 4; then compound 2.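

Among the compounds shown here, replacing 4-(trifluoromethoxy)phenyl with 4-fluorophenyl gives a 2.2-fold higher number from compound 1 to compound 4 (0.35 log units; beyond the scatter) and is the first step in which only this position changes, so this change can now be read on its own. In this assay the substituent at this aromatic carbon does affect the number, yet the shift is modest: with a single fluoro in place of a group of five heavy atoms, compound 4 still gives 50.1 nM and remains far from the number of compound 2. Nothing measured here explains the size or direction of this step.

On these data alone, it remains open how an amine, a carboxylic acid, or simply hydrogen on this same aromatic carbon would compare with fluoro and trifluoromethoxy. Two groups at one position also cannot show a trend that would hold for other substituents there.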